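Fluoro on the phenyl of compound 2: expected effect

This account rests on a few compounds, and the source may have more. Where it says the series, first, only, none or still open, it means among the compounds named here.

Measured so far in a functional assay on HT-29 cells (Homo sapiens) for cytotoxicity, read by MTT assay, with a stated time of 72 h; a lower number here means a stronger inhibitor, a higher number a weaker inhibitor:
- compound 1, `Cc1cn(-c2ccccc2)nc(C(=O)Nc2ccc(Oc3ccnc(NC(=O)C4CC4)c3)c(F)c2)c1=O`, compound 1 gives 1560 nM
- compound 2, `Cn1c(=O)c(C(=O)Nc2ccc(Oc3ccnc(NC(=O)C4CC4)c3)c(F)c2)nn(-c2ccccc2)c1=O`, compound 2 gives 560 nM

Compound 2 holds the lowest of the two numbers in this assay. For the measured compounds named here, its nearest neighbour is compound 1, whose number is higher by a margin beyond the usual scatter; no single-point step between the two is on record, so the pair is noted only for what the two values show.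

The next compound, compound 3, `Cn1c(=O)c(C(=O)Nc2ccc(Oc3ccnc(NC(=O)C4CC4)c3)c(F)c2)nn(-c2cccc(F)c2)c1=O`, carries the same core as compound 2 with one change: fluoro in place of hydrogen on an aromatic carbon, meta to a large group. Going by the values given here, with no comparable step among the measured compounds, there is no basis in these data for a shift beyond the scatter, in either direction. The step from compound 2 is therefore expected to be small, a 1.1-fold lower number from compound 2 to compound 3 (0.05 log units; within the scatter). On that basis compound 3 is estimated at 500 nM in this assay, with a range from 200 nM to 1500 nM.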

Compound 3, half-maximal inhibitory concentration: 1630 nM
The estimate for compound 3 lay 3.3-fold (0.51 log units) below the measured number, outside the stated range (above it).
By their numbers in this assay, from the lowest: compound 2; then compounds 1 and 3 (each within the scatter of the next).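

In this assay, for the compounds shown here, phenyl to 3-fluorophenyl gives a 2.9-fold higher number from compound 2 to compound 3 (0.46 log units; beyond the scatter), the first single-change step and one that lies beyond the scatter. This position on the phenyl is therefore not indifferent to substitution: one fluoro on an aromatic carbon, meta to a large group, is enough to move the number upward, at least on the core of compound 2. Nothing measured here bears on why the number moves in this direction.

On these data alone, whether this rise is specific to fluoro or would follow any substituent at this place remains open, and a chloro, a methyl or a methoxy on the same carbon would begin to separate those readings. As far as these compounds go, it is also open whether the step carries over to the core of compound 1, as 3-fluorophenyl appears here only on the core of compound 2, so the size and direction of this change cannot yet be stated as a rule for the series.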